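Half-life series: cyclohexyl for sec-butyl on the chain

The source may report more compounds than this note shows. Statements on the series, on what has been measured and on what is new or still open speak of the compounds shown alone.

Three compounds of one shared core have been run in an in vitro ADME assay on microsomes from liver (Homo sapiens) for metabolic stability, tested at 5 uM; on this read-out lower numbers stand for a shorter-lived compound and higher numbers for a longer-lived compound. Compound 1 `COCN(c1ccc2c(c1)S(=O)(=O)N=C(c1c(O)c(-c3cccs3)nn(CCC(C)C)c1=O)N2)S(C)(=O)=O` gives 0.183 h in this assay, and compound 2 `CC(C)CCn1nc(-c2ccccc2)c(O)c(C2=NS(=O)(=O)c3cc(NS(C)(=O)=O)ccc3N2)c1=O` gives 0.633 h. Compound 3 `CCC(C)CCn1nc(-c2cccs2)c(O)c(C2=NS(=O)(=O)c3cc(NS(C)(=O)=O)ccc3N2)c1=O` gives > 1 h in this assay, which is a limit of the assay and not a number. Compound 3 thus stands at the limit of > 1 h in this assay, at which 1 of the 3 values shown sits, and its gap to compound 1 and to compound 2 cannot be sized beyond saying that its reported value lies past theirs. Among the measured compounds shown here, no pair among the three differs in one place only, so no single step is resolved.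

Compound 4 `CS(=O)(=O)Nc1ccc2c(c1)S(=O)(=O)N=C(c1c(O)c(-c3cccs3)nn(CCC3CCCCC3)c1=O)N2` is the next compound to be measured in this assay. Against compound 3 the change is cyclohexyl in place of sec-butyl on a saturated chain carbon, two bonds along the chain from an aromatic nitrogen.

For the measured compounds named here, nothing among the measured compounds shows how such a change moves the half-life. The step expected in this assay reads a step that the limit leaves unreadable from compound 3 to compound 4, which is no movement beyond the scatter; the reported value for compound 3 is itself only a limit, so the starting point is uncertain. Compound 4 is therefore estimated at 1.2 h, within 0.5 h to 3 h, and a second limit report is considered likely.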

Compound 4, half-life: > 1 h
Compound 4 was reported as a limit; the forecaster's own chance of this, stated with the estimate: 60%; the middle value lies beyond the limit too.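

Compound 4 gives > 1 h, which is a limit of the assay and not a number. Compound 3 is also reported only as a limit, so no step can be read between compound 3 and compound 4: the limit of > 1 h in this assay, at which 2 of the 4 values shown sit.

The compounds shown leave open how far the half-life of either compound lies past that limit, and whether cyclohexyl in place of sec-butyl moves it at all.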